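Iodinated hydrazides: fluoro to chloro swap on HepG2 cytotoxicity

The source may hold more compounds than are shown below. What is called first, only, known or untested is meant among the compounds shown, and "the series" means these compounds.

Compound 1 `O=C(N/N=C/c1cc(I)c(O)c(I)c1)c1ccc(F)cc1` and compound 2 `O=C(N/N=C/c1cc(I)c(O)c(I)c1)c1ccc(Cl)cc1` share one core and differ by chloro in place of fluoro on an aromatic carbon. In a functional assay on HepG2 cells (Homo sapiens) for cytotoxicity, with a stated time of 24 h (a higher number here means a weaker inhibitor, a lower number a stronger inhibitor), compound 1 gives 117000 nM. Compound 2 gives > 100000 nM in this assay, which is a limit and not a number. Hence a step that the limit leaves unreadable from compound 1 to compound 2, because the limit of > 100000 nM in this assay, at which 1 of the 3 values shown sits, is where compound 2 was read. Compound 3 `O=C(NNCc1cc(I)cc(I)c1O)c1ccc(F)cc1` stands on a second core; the difference between the two cores is not broken down here. In this assay compound 3 gives 52200 nM, a lower number than compound 1 and beyond the scatter. Compound 4 `O=C(NNCc1cc(I)cc(I)c1O)c1ccc(Cl)cc1` carries the same change: chloro in place of fluoro on an aromatic carbon. The step from compound 3 to compound 4 is expected to be a 1.5-fold higher number from compound 3 to compound 4 (0.19 log units; within the scatter), toward a higher number. That expectation rests on a step that the limit leaves unreadable from compound 1 to compound 2. Compound 4 is accordingly estimated at 80000 nM, between 35000 nM and 200000 nM.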

Compound 4, half-maximal inhibitory concentration: 52200 nM
Compound 4: middle estimate off by 1.5-fold (0.19 log units), on the high side; the measured number falls inside the stated range.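

In this assay, chloro in place of fluoro on the core of compound 3 gives no change at the digits printed from compound 3 to compound 4 (within the scatter). On the core of compound 1, the same change cannot be read, since compound 2 stands at a limit and not a number: the limit of > 100000 nM in this assay, at which 1 of the 4 values shown sits. The change is therefore readable on one core only, which shows no effect on that core within the scatter but neither confirms nor refutes that the change carries from one core to the other.

Open, on these data alone, is how a methoxy group or a carboxylic acid on the same aromatic carbon would read in this assay. Also open, as far as these compounds go, is whether a number in place of the limit for compound 2 would match the step on the other core.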